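The compounds below may be only part of what the source reports. "The series", "measured", "known", "first", "only" and "open" are said of these compounds alone.

Measured in an ADME assay on BEAS-2B cells (Homo sapiens) for cytotoxicity, read by MTT assay, with a stated time of 72 h; a lower number here means a stronger inhibitor of growth, a higher number a weaker inhibitor of growth:
compound 1, `COc1ccc(OC(=O)Nc2ccc([Se]C#N)cc2)cc1`, gives 48400 nM
compound 2, `CCCCCCOC(=O)Nc1ccc([Se][Se]c2ccc(NC(=O)OCCCCCC)cc2)cc1`, gives 6900 nM
compound 3, `N#C[Se]c1ccc(NC(=O)OCc2ccc([N+](=O)[O-])cc2)cc1`, gives 32800 nM

Among these three, compound 1 has the highest number, so it is the weakest inhibitor of growth in this set. Compound 3 lies within the scatter of compound 1, so no order can be read between those two. Compound 2 is the only one that stands apart: its number is lower than that of compound 1 by more than the scatter, making it the stronger inhibitor of growth of the pair.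

Compound 4, `Cc1ccc(OC(=O)Nc2ccc([Se]C#N)cc2)cc1`, has not yet been measured. It differs from compound 1 in one place: methyl in place of methoxy on an aromatic carbon, on an aromatic carbon of a six-membered aromatic ring of carbon only. Nothing in the measured set shows a step of this kind, so there is no direct guide to the direction or size. The expectation is a step no larger than the scatter, with compound 4 near compound 1 in this assay. On that basis compound 4 is estimated at 40000 nM, within a range from 15000 nM to 100000 nM, which means an expected step of a 1.2-fold lower number from compound 1 to compound 4 (0.08 log units; within the scatter).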

Compound 4, concentration for total growth inhibition: 15300 nM
The estimate for compound 4 lay 2.6-fold (0.42 log units) above the measured number; low and high end bracket the measured number.
By their numbers in this assay, from the lowest: compound 2; then compound 4; then compounds 3 and 1 (each within the scatter of the next).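

Within the data shown here, exchanging methoxy for methyl on an aromatic carbon, para to a large group, gives the first step in this set that can be read from a change in one place. In this assay this exchange produces a 3.2-fold lower number from compound 1 to compound 4 (0.50 log units; beyond the scatter), so this position is not indifferent to the group it carries, and here methyl goes with the stronger inhibition of growth. Nothing available gives a cause for this step.

The compounds shown leave open how other groups at this position would behave, such as an ethyl group, a chlorine atom or an amine, so a single step fixes no trend. They also leave open whether methyl in place of methoxy would give a step of similar size and direction on another core.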